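The source may report more compounds than this note shows. Statements on the series, on what has been measured and on what is new or still open speak of the compounds shown alone.

Measured so far:
compound 1 `CC(=O)O[C@H](C/C(C)=C/CO)[C@@]1(C)[C@H](C)CC=C2[C@@H]1CCCC2(C)C`: > 30000 nM (a limit)
compound 2 `C/C(=C\CO)C[C@@H](O)[C@@]1(C)[C@H](C)CC=C2[C@@H]1CCCC2(C)C`: > 30000 nM (a limit)

In a functional assay on MOLT-3 cells (Homo sapiens) for cytotoxicity, read by MTT assay, with a stated time of 72 h (on this read-out lower numbers stand for stronger inhibition and higher numbers for weaker inhibition), compound 1 gives > 30000 nM, which is a limit and not a number. Among the compounds with values here, the only other value shown is a limit too, so the series so far consists of the limit of > 30000 nM in this assay, at which 2 of the 2 values shown sit.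

Compound 3 `COC(=O)/C=C(\C)C[C@@H](OC(C)=O)[C@@]1(C)[C@H](C)CC=C2[C@@H]1CCCC2(C)C` keeps the acetyl and the core of compound 1, but carries methoxycarbonyl in place of hydroxymethyl on a double-bonded chain carbon bound to a double-bonded chain carbon.

Within the data shown here, the one measured step is a step that the two limits leave unreadable from compound 1 to compound 2. It concerns a different change, hydrogen in place of acetyl, and offers no size to carry over. No direction can therefore be set, and no step beyond the scatter is expected in this assay. Compound 1 reads > 30000 nM, so the expectation for compound 3 stays close to that limit, and a reported limit is the likeliest result. The expected change is a number no higher from compound 1 to compound 3 (the limit leaves the size open). For compound 3 the estimated value is 30000 nM. The expected range for compound 3 runs from 12000 nM to 60000 nM.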

Compound 3, half-maximal inhibitory concentration: > 30000 nM
Compound 3 ended at the assay's limit (the forecaster's own chance of this, stated with the estimate: 75%); the middle value lies on the limit itself.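

Compound 3, like compound 1, gives only a limit in this assay, so the step between them cannot be read, and neither can the step from compound 1 to compound 2. All the results shown are limits: the limit of > 30000 nM in this assay, at which 3 of the 3 values shown sit. The compounds shown leave open whether any change to this shared core gives a measurable value.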